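Benzylsulfanyl in place of methylsulfanyl: expected step

The source may hold more compounds than are shown below. What is called first, only, known or untested is meant among the compounds shown, and "the series" means these compounds.

In a functional assay on KB cells (Homo sapiens) for inhibition (on this read-out higher numbers stand for weaker inhibition and lower numbers for stronger inhibition), compound 1 `OC[C@H]1OC(n2c(Br)nc3c(Cl)cc(Cl)cc32)[C@H](O)[C@@H]1O` gives 150000 nM. Compound 3 `CSc1nc2c(Cl)cc(Cl)cc2n1C1O[C@H](CO)[C@@H](O)[C@H]1O` gives 270000 nM, which lies within the scatter of the value for compound 1. Compound 2 `OC[C@H]1OC(n2c(S)nc3c(Cl)cc(Cl)cc32)[C@H](O)[C@@H]1O` is reported only as a limit, > 300000 nM. Any reading for the next compound has to be taken against (the limit of > 300000 nM in this assay, at which 1 of the 3 values shown sits).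

Compound 4 `OC[C@H]1OC(n2c(SCc3ccccc3)nc3c(Cl)cc(Cl)cc32)[C@H](O)[C@@H]1O` differs from compound 3 by one change: phenyl in place of hydrogen on a saturated chain carbon bound to a sulfur. This turns methylsulfanyl into benzylsulfanyl.

Within the data shown here, three measured steps bear on this change: an at least 2.0-fold higher number from compound 1 to compound 2 (0.30 log units; that floor lies within the scatter), a 1.8-fold higher number from compound 1 to compound 3 (0.26 log units; within the scatter) and an at least 1.1-fold lower number from compound 2 to compound 3 (0.04 log units; that floor lies within the scatter). The closest is the last, methyl in place of hydrogen on a sulfur. All three lie within the scatter, and two of them are only floors set by the limit. None of them tests a phenyl group, so the series gives no direct measure of this change. With bromo, sulfanyl and methylsulfanyl all giving weak readings, no size of step beyond the scatter can be argued for in this assay.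

The expected step is a 1.5-fold lower number from compound 3 to compound 4 (0.18 log units; within the scatter), which is no change beyond the scatter. For compound 4 the estimated value is 180000 nM, with an expected range of 70000 nM to 400000 nM.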

Compound 4, half-maximal inhibitory concentration: 122000 nM
For compound 4 the middle estimate is 1.5-fold (0.17 log units) above the measured one; the measured number falls inside the stated range.
By their numbers in this assay, from the lowest: compounds 4, 1 and 3 (each within the scatter of the next, the first and the last beyond it). At a limit, above all of these: compound 2.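

In this assay, among these compounds, phenyl on the saturated chain carbon bound to a sulfur gives the first step that clears the scatter, a 2.2-fold lower number from compound 3 to compound 4 (0.35 log units; beyond the scatter), so this position is not fully flat, although the step is only modest. Against the sulfanyl compound the reading is an at least 2.4-fold lower number from compound 2 to compound 4 (0.39 log units; beyond the scatter), and this is only a floor, since compound 2 is reported as a limit: the limit of > 300000 nM in this assay, at which 1 of the 4 values shown sits. Against bromo the change gives a 1.2-fold lower number from compound 1 to compound 4 (0.09 log units; within the scatter), so benzylsulfanyl is not separated from bromo at this position, and the benzyl gain over methyl does not take the series clear of the bromo compound.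

From the compounds shown here alone, whether the step needs the aromatic ring or only a larger group on the sulfur stays open, and a cyclohexylmethyl group or a longer alkyl chain there would separate the two readings. Also open, going by these compounds, is how an amine or a carboxylic acid at the same place would read in this assay, and whether any group here can move the number well beyond the narrow band seen so far.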